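Series notes: compound 2 to compound 3 in liver microsomes

A few compounds are considered here, and "the series" means these few. Any claim that something is new, unique, unknown or untested is made for them only; others in the source may bear on it.

Among the compounds with values here, compound 2 `CC(C)C(c1ccc(-c2ccc3cccc(F)c3c2)[nH]c1=O)N1CCN/C1=N\C#N` gives 0.632 h in an ADME assay on microsomes from liver (Homo sapiens) for metabolic stability (a lower number here means that the compound disappears faster, a higher number that the compound lasts longer), the lowest of the two numbers so far. Compound 1 `CCC(CC)(c1nnc[nH]1)c1ccc(-c2ccc3cc(F)cc(F)c3c2)[nH]c1=O` in this assay gives 1.76 h, a gap beyond the usual scatter of the measurement. Compound 3 `CC(C)C(c1ccc(-c2ccc3cccc(F)c3c2)[nH]c1=O)N1CCNC1=O` differs from compound 2 in one place: a group of 6 heavy atoms (3 carbon, 2 nitrogen, 1 oxygen; one five-membered non-aromatic ring with 2 hetero atoms) in place of a group of 8 heavy atoms (4 carbon, 4 nitrogen; one five-membered non-aromatic ring with 2 hetero atoms), on a saturated chain carbon bound to an aromatic carbon and a saturated chain carbon. Within the data shown here, no measured pair carries this change, so the size of the step is open. A modest rise is expected, a 1.4-fold higher number from compound 2 to compound 3 (0.15 log units; within the scatter), though the step may also fall within the scatter. In this assay compound 3 is estimated at 0.9 h, with a range from 0.4 h to 2 h.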

Compound 3, half-life: 1.03 h
Estimate against measurement, compound 3: 1.1-fold (0.06 log units) below; measured number inside the range.
By their numbers in this assay, from the lowest: compounds 2, 3 and 1 (each within the scatter of the next, the first and the last beyond it).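

At the saturated chain carbon bound to an aromatic carbon and a saturated chain carbon, 2-oxoimidazolidin-1-yl in place of the group of 8 heavy atoms gives, in this assay, a 1.6-fold higher number from compound 2 to compound 3 (0.21 log units; within the scatter). This exchange of one five-membered non-aromatic ring for another therefore does not separate the two compounds in half-life. Nothing available speaks to a cause for this result.

On these data alone, whether an open-chain urea or a simple amine on this carbon would move the half-life beyond the scatter remains open. So does whether a carboxylic acid there would.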